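The compounds below may be only part of what the source reports. "The series", "measured", "known", "first", "only" and "open" are said of these compounds alone.

Compound 1 `CC(C)c1cn2ccccc2c1S(=O)(=O)c1ccc(OCCCNCc2ccccc2)cc1`: 22.8 nM
Compound 2 `CC(C)c1cn2ccccc2c1S(=O)(=O)c1ccc(OCCCN2CCN(c3ccccc3)CC2)cc1`: 205 nM

In a functional assay (aorta) with Rattus norvegicus as the target (a lower number here means a stronger inhibitor, a higher number a weaker inhibitor), compound 2 holds the higher of the two numbers, at 205 nM. Compound 3 `CC(C)c1cn2ccccc2c1S(=O)(=O)c1ccc(OCCCN2CCC(c3ccccc3)CC2)cc1` differs from it in one place: 4-phenylpiperidin-1-yl in place of 4-phenylpiperazin-1-yl on a saturated chain carbon, three bonds along the chain from an oxygen on an aromatic ring. Among the compounds with values here, only one measured step bears on this, a 9.0-fold higher number from compound 1 to compound 2 (0.95 log units; beyond the scatter). It changes the same place but is a different exchange, so it shows that the place matters without measuring this change. Since that step leaves compound 2 at the high end, a smaller, modest move towards a lower number is expected, an estimated 2.3-fold lower number from compound 2 to compound 3 (0.36 log units; beyond the scatter). The estimated value for compound 3 is 90 nM, within a range of 25 nM to 320 nM.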

Compound 3, half-maximal inhibitory concentration: 80.9 nM
For compound 3 the middle estimate is 1.1-fold (0.05 log units) above the measured one, within the range that was stated.
By their numbers in this assay, from the lowest: compound 1; then compound 3; then compound 2.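

In this assay, 4-phenylpiperidin-1-yl in place of 4-phenylpiperazin-1-yl gives a change beyond the scatter (a 2.5-fold lower number from compound 2 to compound 3 (0.40 log units; beyond the scatter)). The place therefore responds even to an exchange within the ring, with the phenyl ring kept. Benzylamino still holds the lowest number of the three, as the other new step shows (a 3.5-fold higher number from compound 1 to compound 3 (0.55 log units; beyond the scatter)).

No evidence accompanies these results to account for either step. Going by these compounds, whether a 4-benzylpiperidin-1-yl group or a longer chain would bring the number nearer to that of compound 1 remains open.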